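A few compounds are considered here, and "the series" means these few. Any claim that something is new, unique, unknown or untested is made for them only; others in the source may bear on it.

Measured so far in an ADME assay on HEK293 cells (Homo sapiens) for cytotoxicity; on this read-out lower numbers stand for stronger inhibition and higher numbers for weaker inhibition:
compound 1 `CCCCCCCCCCCCCCNC(=O)[C@H](CO)/N=C/c1cccc(C)c1`: 51100 nM
compound 2 `CCCCCCCCCCCCCCNC(=O)[C@H](CO)/N=C/c1ccccc1[N+](=O)[O-]`: 82600 nM
compound 3 `CCCCCCCCCCCCCCNC(=O)[C@H](CO)/N=C/c1ccccc1Cl`: 94900 nM

Compound 3 does not stand apart from the other two, as a 1.9-fold higher number from compound 1 to compound 3 (0.27 log units; within the scatter) and a 1.1-fold higher number from compound 2 to compound 3 (0.06 log units; within the scatter) both lie within the scatter. The next change leads to compound 4 `CCCCCCCCCCCCCCNC(=O)[C@H](CO)/N=C/c1ccccc1O`, with hydroxy in place of chloro on an aromatic carbon, ortho to a large group (hydroxy in place of chloro on an aromatic carbon). Among the measured compounds shown here, no measured compound carries hydroxy, so this exact exchange has not been tested. The closest evidence is the exchange of nitro for chloro, a 1.1-fold higher number from compound 2 to compound 3 (0.06 log units; within the scatter). The aryl exchange a 1.6-fold higher number from compound 1 to compound 2 (0.21 log units; within the scatter) also stayed within the scatter. All three measured changes on the aromatic ring are therefore small, and the long chain and the rest of the shared core stay unchanged in compound 4. No shift beyond the scatter is expected, and the direction is uncertain. The expected change is a 1.3-fold lower number from compound 3 to compound 4 (0.12 log units; within the scatter). For compound 4 the estimated value is 72000 nM, with an expected range from 32000 nM to 150000 nM.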

Compound 4, half-maximal inhibitory concentration: 80800 nM
For compound 4 the middle estimate is 1.1-fold (0.05 log units) below the measured one, within the range that was stated.
By their numbers in this assay, from the lowest: compounds 1, 4, 2 and 3 (each within the scatter of the next).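

In this assay, hydroxy in place of chloro adds a hydrogen-bond donor and a hydrogen-bond acceptor on an aromatic carbon ortho to a large group, yet a 1.2-fold lower number from compound 3 to compound 4 (0.07 log units; within the scatter) shows no shift beyond the scatter. The other comparisons agree: a 1.0-fold lower number from compound 2 to compound 4 (0.01 log units; within the scatter) for hydroxy in place of nitro and a 1.6-fold higher number from compound 1 to compound 4 (0.20 log units; within the scatter) for 2-hydroxyphenyl in place of 3-methylphenyl are both printed as within the scatter, so the donor-bearing aryl group does not separate from the other three in this set. No supporting measurement bears on this result.

Going by these compounds, whether an amine or a carboxylic acid on this aromatic carbon would give a step beyond the scatter remains open. So does the outcome of a shorter chain in place of the long chain shared by compounds 1 to 4.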